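Pyridin-4-yl in place of phenyl on the amide nitrogen

The source may hold more compounds than are shown below. What is called first, only, known or untested is meant among the compounds shown, and "the series" means these compounds.

In an ADME assay on MRC5 cells (Homo sapiens) for inhibition, with a stated time of 72 h (a lower number here means that less compound is needed, a higher number that more compound is needed for the effect), compound 1 (`COc1cccc(OC)c1C(=O)Nc1c[nH]nc1C(=O)N[C@H]1CC[C@H](OC)CC1`) gives 31000 nM. Compound 2 (`COc1cccc(OC)c1C(=O)Nc1c[nH]nc1C(=O)NCc1ccccn1`) gives > 50000 nM, which is a limit and not a number. Compound 3 (`COc1cccc(OC)c1C(=O)Nc1c[nH]nc1C(=O)Nc1ccccc1`) gives > 50000 nM, which is also a limit and not a number. Compound 3 therefore stands at the limit of > 50000 nM in this assay, at which 2 of the 3 values shown sit.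

Compound 4 (`COc1cccc(OC)c1C(=O)Nc1c[nH]nc1C(=O)Nc1ccncc1`) carries pyridin-4-yl in place of phenyl on an amide-type nitrogen. Two measured steps at that nitrogen, an at least 1.6-fold higher number from compound 1 to compound 2 (0.20 log units; that floor lies within the scatter) and an at least 1.6-fold higher number from compound 1 to compound 3 (0.20 log units; that floor lies within the scatter), give floors only. Among the compounds with values here, no measured step reads out this exact exchange. Given a step that the two limits leave unreadable from compound 2 to compound 3, no step beyond the scatter is expected in this assay, in either direction. Compound 4 is expected at 50000 nM, with an estimated range of 20000 nM to 100000 nM, and the read-out will probably be only a limit. That estimate means an expected a number no higher from compound 3 to compound 4 (the limit leaves the size open).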

Compound 4, half-maximal effective concentration: > 50000 nM
Compound 4 was reported as a limit; the forecaster's own chance of this, stated with the estimate: 75%; the middle value sits exactly at the limit.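

In this assay, placing pyridin-4-yl on the amide-type nitrogen in place of phenyl brings in a ring nitrogen and one hydrogen-bond acceptor, yet compound 4 gives > 50000 nM, which is a limit of the assay and not a number. Within the data shown here, the steps to compound 4 from compound 2 and from compound 3 cannot be read, and the one readable step is an at least 1.6-fold higher number from compound 1 to compound 4 (0.20 log units; that floor lies within the scatter). Compound 4 therefore adds a third compound at this position without a measured number, joining compound 2 and compound 3: the limit of > 50000 nM in this assay, at which 3 of the 4 values shown sit.

Of the compounds shown, only compound 1, with 4-methoxycyclohexyl, gives a number, so any true differences among compound 2, compound 3 and compound 4 remain open. Also open, as far as these compounds go, is whether 4-aminocyclohexyl or a longer alkyl chain at this nitrogen would give a measurable number.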